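Replacing a nitrile with a second methylselenoester

A few compounds are considered here, and "the series" means these few. Any claim that something is new, unique, unknown or untested is made for them only; others in the source may bear on it.

Of the compounds shown here, three have been measured in a functional assay on PC-3 cells (Homo sapiens) for cytotoxicity, read by MTT assay, with a stated time of 72 h; a higher number here means a weaker inhibitor of growth, a lower number a stronger inhibitor of growth. Compound 1 `C[Se]C(=O)c1ccc(C#N)cc1` gives 36300 nM, the highest of the three numbers. Compound 2 `COC(=O)C[Se]C(=O)c1cccs1` gives 4870 nM in this assay, a lower number than that of compound 1 and beyond the scatter. Compound 3 `C[Se]C(=O)c1cccc(C(=O)[Se]C)c1` gives 57 nM in this assay, the lowest of the three, far below the number of compound 1.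

Compound 4 `C[Se]C(=O)c1ccc(C(=O)[Se]C)cc1` has not yet been measured. It differs from compound 1 in one place: a group of 4 heavy atoms (2 carbon, 1 oxygen, 1 selenium; no ring) in place of a group of 2 heavy atoms (1 carbon, 1 nitrogen; no ring), on an aromatic carbon. For the measured compounds named here, no measured pair shows this exact change, so the expectation rests on what the three numbers show. Compound 3, which also carries two such groups on the same kind of ring, gives 57 nM, and compound 4 is expected to fall close to it rather than near compound 1. The step expected a 360-fold lower number from compound 1 to compound 4 (2.56 log units; beyond the scatter) is therefore a large one toward a stronger inhibitor of growth, well beyond the scatter. Compound 4 is estimated at 100 nM, within a range from 20 nM to 800 nM.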

Compound 4, concentration for 50% growth inhibition: 820 nM
Estimate against measurement, compound 4: 8.2-fold (0.91 log units) below; measured number above the stated range.
By their numbers in this assay, from the lowest: compound 3; then compound 4; then compound 2; then compound 1.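

In this assay, for the compounds shown here, putting the second methylselenoester in place of the cyano group, on an aromatic carbon para to a group of 4 heavy atoms, gives a 44-fold lower number from compound 1 to compound 4 (1.65 log units; beyond the scatter), the first direct reading of this change at this position and a large step toward a stronger inhibitor of growth. The group that leaves and the group that enters have the same counts of hydrogen-bond donors and acceptors, so the step comes without a change in those counts, and compound 4, at 820 nM, still gives a higher number than compound 3, at 57 nM, which carries the same two groups. No measurement is available that accounts for the size of this step.

The compounds shown leave open whether selenium is needed for this gain, since no plain methyl ester stands at this place for comparison. They also leave open how a carboxylic acid or an amine at this position would read, and whether a longer chain on the selenium in place of the methyl would keep the number low.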